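The compounds below may be only part of what the source reports. "The series", "measured", "known", "first", "only" and "open" are said of these compounds alone.

In a functional assay on ZR-75-1 cells (Homo sapiens) for cytotoxicity, read by MTT assay, with a stated time of 72 h (a higher number here means that more compound is needed for the effect, a lower number that less compound is needed), compound 1 (`CCc1cccc2c(OC)c(-c3occ(C)c3C(=O)OC)ccc12`) gives 1.3 ug/mL and compound 2 (`CCOC(=O)c1c(C)coc1-c1ccc2c(CC)cccc2c1OC`) gives 3.9 ug/mL while compound 3 (`CCc1cccc2c(OC)c(-c3occ(C)c3COC)ccc12`) gives 9.7 ug/mL as the highest of the three numbers.

Compound 4 (`CCc1cccc2c(OC)c(-c3occ(C)c3CBr)ccc12`) changes compound 3 as follows: bromo in place of methoxy on a saturated chain carbon bound to an aromatic carbon with bromo in place of methoxy on a saturated chain carbon bound to an aromatic carbon.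

Among the compounds with values here, no measured step makes this exchange, so the evidence is indirect. The nearest steps are a 7.5-fold higher number from compound 1 to compound 3 (0.87 log units; beyond the scatter) and a 2.5-fold higher number from compound 2 to compound 3 (0.40 log units; beyond the scatter) which put methoxymethyl in place of methoxycarbonyl and ethoxycarbonyl. Both are modest and beyond the scatter. The remaining step, a 3.0-fold higher number from compound 1 to compound 2 (0.48 log units; beyond the scatter) is also modest but only alters the ester.

Changes around this carbon have therefore moved the number modestly, and compound 3 already has the highest value. A modest move toward a lower number is the working expectation, though a result within the scatter remains possible. The expected size is a 2.2-fold lower number from compound 3 to compound 4 (0.33 log units; beyond the scatter) as an estimate in this assay with wide uncertainty. For compound 4 the estimated value is 4.5 ug/mL with an expected range from 1.3 ug/mL to 14 ug/mL on present data.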

Compound 4, concentration for half-maximal effect: 4.6 ug/mL
Beside the measured number, compound 4's estimate is 1.0-fold (0.01 log units) below it, within the range that was stated.
By their numbers in this assay, from the lowest: compound 1; then compounds 2 and 4 (each within the scatter of the next); then compound 3.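

In this assay, within the data shown here, the exchange of bromo for methoxy on a saturated chain carbon bound to an aromatic carbon gives a 2.1-fold lower number from compound 3 to compound 4 (0.32 log units; beyond the scatter) and is the first step here that leaves this carbon in place and changes only what it carries, so the number responds at this position with no carbonyl group present. Bromomethyl and ethoxycarbonyl are not separated, with a 1.2-fold higher number from compound 2 to compound 4 (0.07 log units; within the scatter) as their step, whereas a 3.5-fold higher number from compound 1 to compound 4 (0.55 log units; beyond the scatter) keeps compound 1 the lowest of the four, so only the methoxycarbonyl compound stands clear of bromomethyl. No measurement on hand gives a reason for these differences.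

On these data alone, it remains open how a hydroxyl, an amine or a carboxylic acid at this position would compare with methoxy and bromo. Whether chloro would follow bromo, and whether a longer chain would be accommodated in place of bromomethyl, also stays unresolved.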